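This account rests on a few compounds, and the source may have more. Where it says the series, first, only, none or still open, it means among the compounds named here.

Measured so far:
- compound 1 `Cc1cccc(NC(=O)C2(C(=O)Nc3ccc(Nc4ncc5cc(C(=O)N(C)C)n(C6CCCC6)c5n4)cc3)CC2)c1` gives 35.2%
- compound 2 `CN(C)C(=O)c1cc2cnc(Nc3ccc(NC(=O)C4(C(=O)Nc5ccccc5F)CC4)cc3)nc2n1C1CCCC1` gives 79.1%

In a functional assay on A549 cells (Homo sapiens) for inhibition, read by CCK-8 assay, with a stated time of 72 h, tested at 1 uM (on this read-out higher numbers stand for more inhibition of growth at the one concentration tested and lower numbers for less inhibition of growth), compound 2 stands highest of the two compounds measured, at 79.1%. Compound 3 `CN(C)C(=O)c1cc2cnc(Nc3ccc(NC(=O)C4(C(=O)Nc5cccc(Cl)c5)CC4)cc3)nc2n1C1CCCC1` has 3-chlorophenyl in place of 2-fluorophenyl on an amide-type nitrogen, (3-chlorophenyl in place of 2-fluorophenyl on an amide-type nitrogen). For the measured compounds named here, only one measured step bears on this change. It exchanges 3-methylphenyl for 2-fluorophenyl at that same nitrogen and is large, a number 43.9 percentage points higher from compound 1 to compound 2 (beyond the scatter). The group entering compound 3 resembles the 3-methylphenyl of compound 1 more in name than the group it replaces, though a single step cannot show how far that carries. A sizeable fall is therefore expected, smaller than that measured step, and the estimated step is a number 27.1 percentage points lower from compound 2 to compound 3 (beyond the scatter). For compound 3 the estimate is 52%, with an expected range from 28% to 78%.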

Compound 3, percent growth inhibition at one concentration: 8.3%
The estimate for compound 3 lay 43.7 percentage points above the measured number, outside the stated range (below it).
By their numbers in this assay, from the lowest: compound 3; then compound 1; then compound 2.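

In this assay, 3-chlorophenyl in place of 2-fluorophenyl on the amide-type nitrogen gives a number 70.8 percentage points lower from compound 2 to compound 3 (beyond the scatter) and so shows that this position can also lose most of the inhibition seen with compound 2. Chloro in place of methyl on an aromatic carbon gives a number 26.9 percentage points lower from compound 1 to compound 3 (beyond the scatter) as a further modest change, so the outcome at this position depends on the substituent itself and not only on its place on the phenyl ring, and both compounds with a substituted phenyl other than 2-fluorophenyl lie well under compound 2. Nothing available explains why these exchanges change growth inhibition so strongly.

The compounds shown do not separate the identity of the halogen from its place on the ring. Going by these compounds, it remains open how 2-chlorophenyl, 3-fluorophenyl or unsubstituted phenyl would stand on this nitrogen.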